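Tetrazole in place of carboxy on a shortened chain

The source may report more compounds than this note shows. Statements on the series, on what has been measured and on what is new or still open speak of the compounds shown alone.

Of the compounds shown here, three sharing one core have been measured in an assay on isolated protein for binding affinity to leukotriene B4 receptor 1 (Homo sapiens), tested at 1 uM; a higher number here means more inhibition at the concentration tested (going by the name of the read-out), a lower number less inhibition. Compound 1 `CCc1cc(C(C)=O)c(O)cc1OCCCCC(C)(C)C#N` gives 30%, and compound 2 `CCc1cc(C(C)=O)c(O)cc1OCCCCCCC(C)(C)C#N` gives 30%; the step of no change at the digits printed from compound 1 to compound 2 (within the scatter) shows that lengthening the chain between the two nitriles made no difference. Compound 3 `CCc1cc(C(C)=O)c(O)cc1OCCCCCC(C)(C)C(=O)O` gives 73%, the highest of the three numbers, standing clear of both others: a number 43 percentage points higher from compound 1 to compound 3 (beyond the scatter) and a number 43 percentage points higher from compound 2 to compound 3 (beyond the scatter) are large steps in the same direction, both tied to a carboxy group entering where a nitrile had been.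

Compound 4 `CCc1cc(C(C)=O)c(O)cc1OCCCC(C)(C)c1nnn[nH]1` differs from compound 3 as follows: 1-(1H-tetrazol-5-yl)-1-methylethyl in place of 3-carboxy-3-methylbutyl on a saturated chain carbon, three bonds along the chain from an oxygen on an aromatic ring. Within the data shown here, no measured step involves a tetrazolyl group, so the carboxy-to-tetrazole exchange itself is uncovered by the data; the only chain-length comparison on record, from compound 1 to compound 2, showed no change within the scatter. With the carboxy group gone, part of the large gain seen in a number 43 percentage points higher from compound 1 to compound 3 (beyond the scatter) might be lost, but there is no measurement to size that loss.

Compound 4 is therefore expected to land somewhat below compound 3, a step of a number 13 percentage points lower from compound 3 to compound 4 (beyond the scatter) in this assay, with an estimated inhibition of 60% and a range from 35% to 85%.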

Compound 4, a percentage reported as inhibition, at one concentration (the size of the read-out at that concentration, not a potency): 76%
Beside the measured number, compound 4's estimate is 16 percentage points below it, and the stated range covers the measured number.
By their numbers in this assay, from the lowest: compounds 1 and 2 (each within the scatter of the next); then compounds 3 and 4 (each within the scatter of the next).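

At the position three bonds along the chain from an oxygen on an aromatic ring, 1-(1H-tetrazol-5-yl)-1-methylethyl can take the place of 3-carboxy-3-methylbutyl with a number 3 percentage points higher from compound 3 to compound 4 (within the scatter) in this assay, so the two compounds cannot be told apart on this read-out, even though the entering group has a five-membered aromatic ring and no carbonyl. Among these compounds, the large steps of a number 46 percentage points higher from compound 1 to compound 4 (beyond the scatter) and a number 46 percentage points higher from compound 2 to compound 4 (beyond the scatter) show that the high read-out, which the earlier compounds tied only to a carboxy group, also appears with a tetrazole on a different chain, so it is not confined to the carboxylic acid. None of the data shown explains why the two groups give such similar numbers.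

Because the change to compound 4 swaps the end group and alters the chain at once, the compounds shown cannot separate the effect of the tetrazole from that of the chain length, which would take a carboxylic acid on the chain of compound 4 or a tetrazole on the chain of compound 3. Also open, from the compounds shown here alone, is how other end groups at this position, such as a primary amide or a methyl ester, would read in this assay, and every number here is a single-concentration read-out rather than a potency.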